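The source may report more compounds than this note shows. Statements on the series, on what has been measured and on what is new or still open speak of the compounds shown alone.

Working notes on the series, on an in vitro assay on HEK293 cells for binding affinity to 5-hydroxytryptamine receptor 7 (Rattus norvegicus); a higher number here means a weaker inhibitor, a lower number a stronger inhibitor.

Two compounds carry numbers. Compound 1 `COc1ccc2c(c1)CCN(CCCNS(=O)(=O)c1ccc(C)cc1)C2` gives 520 nM in this assay, and compound 2 `CCN(CCCN1CCc2cc(OC)ccc2C1)S(=O)(=O)c1ccc(C)cc1` gives 11 nM. For the measured compounds named here, compound 2 thus stands lowest of the two numbers known, and the single measured step, a 47-fold lower number from compound 1 to compound 2 (1.67 log units; beyond the scatter), is an ethyl in place of hydrogen on a sulfonamide nitrogen.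

Compound 3 `CCN(CCCN1CCc2cc(OC)ccc2C1)S(=O)(=O)c1ccc(OC)cc1` keeps that ethyl and differs from compound 2 only at the aromatic ring: methoxy in place of methyl on an aromatic carbon. Going by the values given here, no measured step touches this ring. Among the compounds with values here, the one step known sits on the sulfonamide nitrogen, a different place and a different kind of change, and it gives no direct guide to the present one. The expectation for compound 3 is therefore a step of a 1.3-fold higher number from compound 2 to compound 3 (0.10 log units; within the scatter) in this assay, which is not beyond the scatter. Compound 3 is estimated at about 14 nM, within a range of 4 nM to 50 nM.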

Compound 3, inhibition constant in the 5-hydroxytryptamine receptor 7 assay: 19 nM
For compound 3 the middle estimate is 1.4-fold (0.13 log units) below the measured one; the range from low to high includes it.
By their numbers in the 5-hydroxytryptamine receptor 7 assay, from the lowest: compounds 2 and 3 (each within the scatter of the next); then compound 1.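

In the 5-hydroxytryptamine receptor 7 assay methoxy in place of methyl on an aromatic carbon gives a 1.7-fold higher number from compound 2 to compound 3 (0.24 log units; within the scatter) at a site para to a large group, so this ring position, which the earlier step on the sulfonamide nitrogen did not reach, takes the change with no shift that can be told from the scatter. In a physicochemical assay for acid dissociation, the same change gives no change at the digits printed from compound 2 to compound 3 (within the scatter) and leaves compound 2 at 7.4 and compound 3 at 7.4 as the printed values. No evidence at hand bears on why the two compounds read alike.

Going by these compounds, whether an amine, a carboxylic acid or a longer chain at this ring position would hold the number in the 5-hydroxytryptamine receptor 7 assay stays open. Also open, on these data alone, is whether 4-methoxyphenyl reads the same with hydrogen in place of ethyl on the sulfonamide nitrogen.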